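From Nitro to Methoxy at the Assay Limit

A few compounds are considered here, and "the series" means these few. Any claim that something is new, unique, unknown or untested is made for them only; others in the source may bear on it.

Compound 1 (`COc1cc(-c2ncnn2-c2ccc([N+](=O)[O-])cc2)cc(OC)c1OC`) was examined in a functional assay on HeLa cells (Homo sapiens) for antiproliferative activity, read by MTT assay, with a stated time of 72 h (a lower number here means a stronger inhibitor, a higher number a weaker inhibitor), and compound 1 gives > 10000 nM as a limit and not a number. In this assay compound 2 (`COc1cc(-n2ncnc2-c2ccc(OC(F)(F)F)cc2)cc(OC)c1OC`) gives > 10000 nM as a limit too. In the same test compound 3 (`CCOc1cccc(-c2ncnn2-c2cc(OC)c(OC)c(OC)c2)c1`) gives > 10000 nM as a limit as well. Compound 1 thus shares the limit of > 10000 nM in this assay, at which 3 of the 3 values shown sit, and has no number of its own.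

Compound 4 (`COc1ccc(-n2ncnc2-c2cc(OC)c(OC)c(OC)c2)cc1`) has not yet been measured. It carries methoxy in place of nitro on an aromatic carbon, para to a large group (methoxy in place of nitro on an aromatic carbon). Going by the values given here, no measured pair shows what this exchange does. A gain in potency beyond the usual scatter is nevertheless expected in this assay on the structural change alone, and a result at the same limit remains possible. The expected change is an at least 10-fold lower number from compound 1 to compound 4 (1.00 log units; beyond the scatter) and it is highly uncertain. For compound 4 the estimate is 1000 nM with 30 nM to 10000 nM as the expected range.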

Compound 4, half-maximal inhibitory concentration: > 10000 nM
Compound 4 was reported as a limit; the forecaster's own chance of this, stated with the estimate: 35%; middle value at least 10-fold (1.00 log units) away from the limit.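

Compound 1 and compound 4 both stand only as limits in this assay, so no step can be read for methoxy in place of nitro: the limit of > 10000 nM in this assay, at which 4 of the 4 values shown sit.

The compounds shown leave open whether this exchange changes potency at all, and how far any compound lies from that limit.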